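This account rests on a few compounds, and the source may have more. Where it says the series, first, only, none or still open, it means among the compounds named here.

Measured compounds:
compound 1, `CC(=O)NCCCc1cccc2c1OCCO2`, 126 nM
compound 2, `CNC(=O)c1cccc2ccc(OC)cc12`, 1260 nM
compound 3, `COc1ccc2cccc(CCC(N)=O)c2c1`, 1000 nM

In an assay (Ovis aries) for binding affinity to melatonin receptor type 1A (Homo sapiens) (on this read-out lower numbers stand for stronger inhibition and higher numbers for weaker inhibition), compound 1 gives the lowest of the three numbers. Compound 3 stands next to it with a higher number, and compound 2 gives the highest number; both gaps to compound 1 lie beyond the scatter. Among the compounds with values here, the only step between measured compounds that differ in one place is a 1.3-fold lower number from compound 2 to compound 3 (0.10 log units; within the scatter), and it concerns the other core.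

Compound 4, `CC(=O)NCCCCc1cccc2c1OCCO2`, is not yet measured. It differs from compound 1 by acetamidomethyl in place of acetamido on a saturated chain carbon, three bonds along the chain from an aromatic carbon, which lengthens the saturated chain that carries the amide by one carbon. Within the data shown here, no measured pair shows this change on the core of compound 1; the step from compound 2 to compound 3 alters the chain on a different core and stays within the scatter, so it gives little guidance. The author therefore expects a moderate rise in this assay for compound 4, as a step of a 2.4-fold higher number from compound 1 to compound 4 (0.38 log units; beyond the scatter), while allowing that the number could stay close to that of compound 1. The estimate for compound 4 is 300 nM, with a range from 80 nM to 1200 nM.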

Compound 4, half-maximal inhibitory concentration: 158 nM
Compound 4: middle estimate off by 1.9-fold (0.28 log units), on the high side, and the stated range covers the measured number.
By their numbers in this assay, from the lowest: compounds 1 and 4 (each within the scatter of the next); then compounds 3 and 2 (each within the scatter of the next).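

In this assay, replacing acetamido with acetamidomethyl on a saturated chain carbon, three bonds along the chain from an aromatic carbon, gives a 1.3-fold higher number from compound 1 to compound 4 (0.10 log units; within the scatter). Within the data shown here, the earlier compounds held no pair on the core of compound 1, so this is the first reading of the chain that carries the amide on that core, and here the added carbon leaves the number unchanged within the scatter. Nothing shown offers a measured reason for this result.

From the compounds shown here alone, whether a still longer chain, or an amine or a carboxylic acid in place of the acetamido group, would keep the number in this range remains open. Going by these compounds, it is also open whether the same lengthening would read alike on the other core, that of compound 2 and compound 3.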